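The source may hold more compounds than are shown below. What is called first, only, known or untested is meant among the compounds shown, and "the series" means these compounds.

Measured so far in an assay on Sf9 cells for inhibition of mitogen-activated protein kinase kinase kinase 14 variant S549D (Homo sapiens), with a stated time of 30 min, in the presence of a further agent that is not named here; a higher number here means a weaker inhibitor, a lower number a stronger inhibitor:
- compound 1 `C=Cc1ccnc(C#Cc2ccc3ncn(-c4ccnc(N)n4)c3c2)n1`: 1580 nM
- compound 2 `C#Cc1cncc(C#Cc2ccc3ncn(-c4ccnc(N)n4)c3c2)n1`: 6310 nM

Compound 2 stands as the higher of the two numbers in this assay; its nearest neighbour is compound 1, and the step of a 4.0-fold higher number from compound 1 to compound 2 (0.60 log units; beyond the scatter) lies beyond the scatter. Compound 3 `C#Cc1cnc(C#Cc2ccc3ncn(-c4ccnc(N)n4)c3c2)nc1` has not been measured. Compound 3 differs from compound 2 by a group of 8 heavy atoms (6 carbon, 2 nitrogen; one six-membered aromatic ring with 2 hetero atoms) in place of a group of 8 heavy atoms (6 carbon, 2 nitrogen; one six-membered aromatic ring with 2 hetero atoms), on a triple-bonded carbon; the two share the same atoms, joined differently. For the measured compounds named here, the only measured step that bears on this, a 4.0-fold higher number from compound 1 to compound 2 (0.60 log units; beyond the scatter), exchanges one such six-membered ring for another on the same triple-bonded carbon and was modest. The present change is smaller in kind, a rearrangement within the ring rather than a change of substituent, so only a small step is expected in this assay, in either direction, most likely within the scatter; the estimated step is a 1.4-fold lower number from compound 2 to compound 3 (0.15 log units; within the scatter). Compound 3 is therefore estimated at 4500 nM, with a range from 1500 nM to 14000 nM.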

Compound 3, half-maximal inhibitory concentration: 25100 nM
Compound 3: middle estimate off by 5.6-fold (0.75 log units), on the low side; measured number outside the range, above it.
By their numbers in this assay, from the lowest: compound 1; then compound 2; then compound 3.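

In this assay, the group on the triple-bonded carbon responds to how its atoms are joined, not only to which atoms it holds: a 4.0-fold higher number from compound 2 to compound 3 (0.60 log units; beyond the scatter), although its counts of heavy atoms, hydrogen-bond acceptors and triple bonds stay identical. The full spread at this place now reaches a 16-fold higher number from compound 1 to compound 3 (1.20 log units; beyond the scatter), so a change of connectivity within the same ring type can separate compounds by a large step. No measurement at hand accounts for these differences.

From the compounds shown here alone, whether this ring arrangement keeps its rank with a nitrile or a methyl group in place of the triple bond outside the ring remains open. Also open, going by these compounds, is whether any group at this place gives a lower number than compound 1.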